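Phenyl for furan-2-yl on compound 2

A few compounds are considered here, and "the series" means these few. Any claim that something is new, unique, unknown or untested is made for them only; others in the source may bear on it.

Compound 1 (`c1ccc(CNc2nc(OCc3ccccc3)c3ccccc3n2)cc1`): 3300 nM
Compound 2 (`CC(C)Nc1nc(NCc2ccco2)nc2ccccc12`): 8300 nM

In an ADME assay on J774.A1 cells (Mus musculus) for inhibition, read by MTT assay, with a stated time of 72 h (on this read-out higher numbers stand for an effect only at larger amounts of compound and lower numbers for an effect already at smaller amounts), compound 2 is the higher of the two at 8300 nM and lies beyond the scatter from compound 1. Compound 3 (`CC(C)Nc1nc(NCc2ccccc2)nc2ccccc12`) differs from compound 2 by phenyl in place of furan-2-yl on a saturated chain carbon bound to a nitrogen on an aromatic ring with phenyl in place of furan-2-yl on a saturated chain carbon bound to a nitrogen on an aromatic ring. For the measured compounds named here, no measured pair isolates this change. Going by the values given here, the only hint is compound 1, also carrying benzyl, at 3300 nM with other groups elsewhere. The expected change is a 1.7-fold lower number from compound 2 to compound 3 (0.22 log units; within the scatter) toward a lower number, within the scatter. For compound 3 the estimated value is 5000 nM with an expected range from 2000 nM to 12500 nM in this measurement.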

Compound 3, half-maximal effective concentration: 7200 nM
Compound 3: the middle estimate sits 1.4-fold (0.16 log units) below what was measured; measured number inside the range.
By their numbers in this assay, from the lowest: compound 1; then compounds 3 and 2 (each within the scatter of the next).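

In this assay, phenyl in place of furan-2-yl on a saturated chain carbon bound to a nitrogen on an aromatic ring gives a 1.2-fold lower number from compound 2 to compound 3 (0.06 log units; within the scatter) and so does not separate these two aromatic rings at this position. Isopropylamino in place of benzyloxy on an aromatic carbon gives a 2.2-fold higher number from compound 1 to compound 3 (0.34 log units; beyond the scatter) and is the only one of these two steps beyond the scatter. No measurement shown here offers a reason for either step.

From the compounds shown here alone, whether a cyclohexyl group or a dimethylamino group on that chain carbon would shift the number remains open. So does whether a longer chain in place of isopropylamino on the aromatic carbon would follow compound 1 or compound 3.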